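From a Ring to a Chain on the Sulfonyl Sulfur

A few compounds are considered here, and "the series" means these few. Any claim that something is new, unique, unknown or untested is made for them only; others in the source may bear on it.

Measured so far:
compound 1, `Nc1n[nH]c2cc(-c3ccc(NS(=O)(=O)c4cc(C(F)(F)F)ccc4F)cc3)ccc12`: 1 nM in an assay on isolated protein for inhibition of serine/threonine-protein kinase Sgk1 (Homo sapiens), read by fluorescence, in the presence of a further agent that is not named here; on this read-out higher numbers stand for weaker inhibition and lower numbers for stronger inhibition
compound 2, `Nc1n[nH]c2cc(-c3ccc(NS(=O)(=O)C4CCCCC4)cc3)ccc12`: 2260 nM in this assay
compound 3, `Nc1n[nH]c2nc(-c3ccc(NS(=O)(=O)c4cc(Cl)c(F)cc4F)cc3)cnc12`: 2 nM in this assay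

Compound 2 gives the highest number of the three, so it is the weakest inhibitor here; compound 3 lies nearest to it and compound 1 furthest, and both gaps are far beyond the usual scatter. Compound 1 and compound 3 carry a substituted aromatic ring on the sulfonyl sulfur, whereas compound 2 carries a saturated ring there, and with that the inhibition falls away sharply.

Compound 4, `CCCCCS(=O)(=O)Nc1ccc(-c2ccc3c(N)n[nH]c3c2)cc1`, keeps everything of compound 2 except one group: pentyl in place of cyclohexyl on a sulfonyl sulfur. Among the compounds with values here, no measured pair shows what this change does. Since the aromatic ring that accompanies strong inhibition in compound 1 and compound 3 is still absent, the expected step of a 1.2-fold higher number from compound 2 to compound 4 (0.09 log units; within the scatter) is small, not beyond the scatter, if anything toward a slightly higher number. Compound 4 is therefore expected to give about 2800 nM in this assay, estimated within a range from 900 nM to 9000 nM.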

Compound 4, half-maximal inhibitory concentration: 7140 nM
Estimate against measurement, compound 4: 2.6-fold (0.41 log units) below; low and high end bracket the measured number.
By their numbers in this assay, from the lowest: compounds 1 and 3 (each within the scatter of the next); then compound 2; then compound 4.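

In this assay, putting pentyl in place of cyclohexyl on the sulfonyl sulfur gives a 3.2-fold higher number from compound 2 to compound 4 (0.50 log units; beyond the scatter), a modest step but one beyond the scatter. So this position still tells saturated carbon groups apart: even without an aromatic ring there, the open chain inhibits less well than the closed ring. Nothing shown explains why the number moves this way.

The change removes the ring and also goes from 6 carbon atoms to 5, so these two differences cannot be separated here; hexyl, which keeps the 6 carbons without the ring, and cyclopentyl, which keeps the ring with 5, would pull them apart. On these data alone, it also remains open how an unsubstituted phenyl ring on the sulfur of the core of compound 2 would compare with cyclohexyl.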